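The source may hold more compounds than are shown below. What is called first, only, known or untested is meant among the compounds shown, and "the series" means these compounds.

Working notes. The shared core appears in compound 1 `CCOc1cc([C@@H](Nc2ccc3cnccc3c2)C(=O)NS(=O)(=O)c2ccccc2)ccc1OC(C)C`, compound 2 `CCOc1cc(C(Nc2ccc3c(N)nccc3c2)C(=O)NS(=O)(=O)c2cccc(N)c2)ccc1OC(C)C` and compound 3 `CCOc1cc([C@@H](Nc2ccc3c(N)nccc3c2)C(=O)NS(=O)(=O)c2cccc(S(N)(=O)=O)c2)ccc1OC(C)C`. In an assay on isolated protein for inhibition of Trypsin (Homo sapiens) (on this read-out higher numbers stand for weaker inhibition and lower numbers for stronger inhibition), compound 1 gives only a limit, > 5000 nM. Compound 2 likewise reaches only the limit of this assay, > 5000 nM. Compound 3 also stops at a limit, > 5000 nM. Compound 2 therefore stands where every value shown stands, namely at the limit of > 5000 nM in this assay, at which 3 of the 3 values shown sit. Compound 4 `CCOc1cc(C(Nc2ccc3c(N)nccc3c2)C(=O)NS(=O)(=O)c2ccc(C)cc2)ccc1OC(C)C` differs from compound 2 by 4-methylphenyl in place of 3-aminophenyl on a sulfonyl sulfur. Among the measured compounds shown here, no step between measured compounds exists to size this change; with the whole set sitting at the limit, no movement beyond the scatter is expected, and the expected step is a step that the limit leaves unreadable from compound 2 to compound 4. Compound 4 is expected in this assay at 10000 nM, within 4000 nM to 40000 nM, most probably again reported only as a limit.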

Compound 4, inhibition constant: 3040 nM
Beside the measured number, compound 4's estimate is 3.3-fold (0.52 log units) above it, outside the stated range (below it).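

In this assay, among the compounds shown here, compound 4 gives 3040 nM, the first value that is a number and not a limit, so a change on the sulfonyl sulfur can yield a readable value. The step reads as an at least 1.6-fold lower number from compound 2 to compound 4 (0.21 log units; that floor lies within the scatter); compound 2 holds only a limit, so the true size of the change from 3-aminophenyl to 4-methylphenyl cannot be read. Compound 1, compound 2 and compound 3 stay at the limit: the limit of > 5000 nM in this assay, at which 3 of the 4 values shown sit.

On these data alone, whether the readable value goes with the methyl group or with the loss of the amino group stays open. Also open, as far as these compounds go, is how this assay reads a carboxylic acid or a longer chain in place of that methyl group.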